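Cytotoxicity notes: from compound 3 toward compound 4

The source may report more compounds than this note shows. Statements on the series, on what has been measured and on what is new or still open speak of the compounds shown alone.

Three compounds of the series have numbers in an ADME assay on HepG2 cells (Homo sapiens) for cytotoxicity, read by luminescence, CellTiter-Glo and ATP content, with a stated time of 72 h; on this read-out lower numbers stand for an effect already at smaller amounts and higher numbers for an effect only at larger amounts of compound. Compound 1 `COc1ccc(Oc2ccc3c(NCCCNCc4cccc(OC)c4O)ccnc3c2)cc1` gives 5500 nM. Among the measured compounds shown here, compound 2 `COc1cccc(CNCCCNc2ccnc3cc(-c4ccccc4)ccc23)c1O` gives 3210 nM; the one recorded step between neighbours, a 1.7-fold lower number from compound 1 to compound 2 (0.23 log units; within the scatter), stays within the scatter. Compound 3 `c1coc(CNCCCNc2ccnc3cc(CC4CCCCC4)ccc23)c1` gives 1700 nM, the lowest of the three numbers, within the scatter of compound 2 and beyond it only against compound 1.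

Compound 4 `COc1cccc(CNCCCNc2ccnc3cc(CC4CCCCC4)ccc23)c1O` keeps everything of compound 3 apart from 2-hydroxy-3-methoxyphenyl in place of furan-2-yl on a saturated chain carbon bound to an amine nitrogen. For the measured compounds named here, no recorded step touches this place: the step from compound 1 to compound 2 alters the group on an aromatic carbon of the shared core, not the group on a saturated chain carbon bound to an amine nitrogen. Compound 2 and compound 3 differ in two places at once, so no single step can be read from them; their values lie within the scatter of each other, which gives no sign that the group on the chain carbon moves the number much. The expected step of a 1.5-fold higher number from compound 3 to compound 4 (0.17 log units; within the scatter) in this assay is therefore none beyond the scatter. The estimate for compound 4 is 2500 nM, with a range from 1000 nM to 6500 nM.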

Compound 4, half-maximal effective concentration: 970 nM
Compound 4: middle estimate off by 2.6-fold (0.41 log units), on the high side, outside the stated range (below it).
By their numbers in this assay, from the lowest: compounds 4, 3, 2 and 1 (each within the scatter of the next, the first and the last beyond it).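

In this assay, among the compounds shown here, the swap of furan-2-yl for 2-hydroxy-3-methoxyphenyl on a saturated chain carbon bound to an amine nitrogen gives the first single-place reading at this position, a 1.8-fold lower number from compound 3 to compound 4 (0.24 log units; within the scatter), so the larger aromatic group, which brings a hydrogen-bond donor that furan-2-yl lacks, leaves the number within the scatter. For the compounds shown here, with this group held constant, compound 4 also gives the first single-place steps beyond the scatter on the aromatic carbon of the shared core, a 3.3-fold lower number from compound 2 to compound 4 (0.52 log units; beyond the scatter) with cyclohexylmethyl in place of phenyl and a 5.7-fold lower number from compound 1 to compound 4 (0.75 log units; beyond the scatter) with cyclohexylmethyl in place of 4-methoxyphenoxy, both modest, so in these four compounds the larger differences arise at the aromatic carbon and not at the chain carbon. No measurement at hand accounts for any of these steps.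

As far as these compounds go, it remains open whether a carboxylic acid or a pyridine ring in place of furan-2-yl on the chain carbon would also stay within the scatter of compound 3. Also open, from the compounds shown here alone, is whether a plain methyl or a cyclohexyl group on the aromatic carbon would give a step of similar size, and whether that step would hold with furan-2-yl on the chain carbon.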